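Removing Two Fluorines From a Triazole Benzyl Group

The source may hold more compounds than are shown below. What is called first, only, known or untested is meant among the compounds shown, and "the series" means these compounds.

Measured compounds so far:
compound 1, `Cc1ccc(S(=O)(=O)N(Cc2cn(Cc3cc(F)ccc3F)nn2)Cc2cn(S(=O)(=O)c3ccccc3)c3ccccc23)cc1`, -6.5%;
compound 2, `Cc1ccc(S(=O)(=O)N(Cc2cn(Cc3ccc(F)cc3F)nn2)Cc2c(C)c3ccccc3n2S(=O)(=O)c2ccc(C)cc2)cc1`, -22%;
compound 3, `Cc1ccc(S(=O)(=O)n2cc(CN(Cc3cccc(F)c3F)S(C)(=O)=O)c3ccccc32)cc1`, -3.3%.

All three compounds were tested in a functional assay on 3T3-L1 cells (Mus musculus) for inhibition, with a stated time of 20 min, tested at 20 uM; on this read-out lower numbers stand for less inhibition and higher numbers for more inhibition at the one concentration tested (going by the name of the read-out). Compound 1 gives -6.5%, compound 3 gives -3.3%, and compound 2 gives -22%. On these numbers compound 2 stands lowest of the three, beyond the scatter from compound 1 and further still from compound 3. None of the three shows inhibition in this assay.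

Compound 4, `Cc1ccc(S(=O)(=O)N(Cc2cn(Cc3ccccc3)nn2)Cc2c(C)c3ccccc3n2S(=O)(=O)c2ccc(C)cc2)cc1`, has not yet been measured. It differs from compound 2 in one place: phenyl in place of 2,4-difluorophenyl on a saturated chain carbon bound to an aromatic nitrogen.

Among the measured compounds shown here, no step between two measured compounds connects to this change, so there is nothing in the data that shows what removing two fluorines from this benzyl group does. With compound 2 at -22% and the other two compounds also below zero in this assay, the step from compound 2 to compound 4 is expected to be small, a number 10 percentage points higher from compound 2 to compound 4 (within the scatter), and not beyond the scatter. Compound 4 is therefore estimated at -12%, with a range from -32% to 8%.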

Compound 4, a percentage reported as inhibition, at one concentration (the size of the read-out at that concentration, not a potency): -5.9%
The estimate for compound 4 lay 6.1 percentage points below the measured number; the measured number falls inside the stated range.
By their numbers in this assay, from the lowest: compound 2; then compounds 1, 4 and 3 (each within the scatter of the next).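

In this assay, among the compounds shown here, the first step that changes one place reads a number 16.1 percentage points higher from compound 2 to compound 4 (beyond the scatter) when 2,4-difluorobenzyl gives way to benzyl, so the read-out does respond to a change at this position, on a saturated chain carbon bound to an aromatic nitrogen. The step does not bring inhibition into view, as compound 4 still gives a negative number, -5.9% in the same assay. No measurement given here bears on why the number moves.

As far as these compounds go, it remains open whether the two fluorines act together or whether one alone would account for the step, and whether the same change on the core of compound 1 would give a step of similar size. The compounds shown also leave open what a methoxy group, an amine or a carboxylic acid on this benzyl ring would do.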